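The source may hold more compounds than are shown below. What is called first, only, known or untested is meant among the compounds shown, and "the series" means these compounds.

Measured so far:
compound 1, `Cn1nnc(-c2sc(-c3cccc(F)c3)nc2O)n1`: 214 nM
compound 2, `CCn1nnc(-c2sc(-c3ccccc3C)nc2O)n1`: 60 nM
compound 3, `CCOC(=O)c1sc(-c2ccccc2)nc1NC(=O)C(F)(F)F`: 7700 nM

The three compounds were tested in an assay on HEK293 cells for inhibition of transient receptor potential cation channel subfamily M member 8 (Homo sapiens), read by FLIPR, with stated times of 5 min and 3 min; a lower number here means a stronger inhibitor, a higher number a weaker inhibitor. Compound 1 gives 214 nM, which places it second highest of the three numbers. Compound 2, with 60 nM, sits nearest to it, at a lower number that lies beyond the usual scatter. Compound 3, with 7700 nM, is furthest away, at a much higher number, again beyond the scatter. Among the compounds with values here, none of these pairs differ in a single place, so no step between them can be read as the effect of one change.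

The next compound, compound 4 `Cc1nnc(-c2sc(-c3cccc(F)c3)nc2O)o1`, is the one unmeasured. It keeps the core of compound 1 and differs in one place:

5-methyl-1,3,4-oxadiazol-2-yl in place of 2-methyl-2H-tetrazol-5-yl on an aromatic carbon

Both groups are small five-membered aromatic rings carrying a methyl. Within the data shown here, with no measured pair showing this kind of swap, the only anchor is the value of compound 1. The step from compound 1 to compound 4 is expected to be small, a 1.4-fold higher number from compound 1 to compound 4 (0.15 log units; within the scatter), perhaps towards a slightly higher number but not clearly beyond the scatter. Compound 4 is therefore estimated at 300 nM in this assay, within a range from 100 nM to 900 nM.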

Compound 4, half-maximal inhibitory concentration: 9100 nM
For compound 4 the middle estimate is 30-fold (1.48 log units) below the measured one, and the stated range ends below it.
By their numbers in this assay, from the lowest: compound 2; then compound 1; then compounds 3 and 4 (each within the scatter of the next).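

In this assay, 5-methyl-1,3,4-oxadiazol-2-yl in place of 2-methyl-2H-tetrazol-5-yl gives a 43-fold higher number from compound 1 to compound 4 (1.63 log units; beyond the scatter), so the aromatic carbon next to the ring sulfur is far from indifferent to which small ring it carries. Both groups are single five-membered aromatic rings with a methyl and the same number of heavy atoms, differing in their ring hetero atoms, so a close match in size and outline does not ensure a similar result here. No measurement bears on why this exchange weakens inhibition so strongly, and the step itself gives no explanation.

The compounds shown do not tell how a carboxylic acid or a primary amide would compare with these two rings on the same carbon. Within the data shown here, they also leave open whether this exchange would give a step of similar size if the other substituent on the shared core were changed, since only this one pair shows it.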